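A Benzofuran Replaces Iodine on a Nucleoside Core

The compounds below may be only part of what the source reports. "The series", "measured", "known", "first", "only" and "open" are said of these compounds alone.

Measured so far:
compound 1 `COc1ncnc2c1c(I)cn2[C@@H]1O[C@H](CO)[C@@H](O)[C@H]1O` gives > 20000 nM.
compound 2 `O=c1[nH]cnc2c1c(-c1ccsc1)cn2[C@@H]1O[C@H](CO)[C@@H](O)[C@H]1O` gives > 20000 nM.

For compound 1 the value > 20000 nM in a functional assay on CEM-DNR-bulk cells (Homo sapiens), read by MTT assay, with a stated time of 72 h (a higher number here means a weaker inhibitor, a lower number a stronger inhibitor), is a limit of the assay and not a measured number. For compound 2 the value > 20000 nM is likewise a limit. Everything measured so far sits at the limit of > 20000 nM in this assay, at which 2 of the 2 values shown sit, so compound 1 cannot be ranked against anything: the two compounds share the same limit and neither is known to be stronger or weaker.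

The unmeasured compound 3 `COc1ncnc2c1c(-c1cc3ccccc3o1)cn2[C@@H]1O[C@H](CO)[C@@H](O)[C@H]1O` keeps the core of compound 1 and differs from it by 1-benzofuran-2-yl in place of iodo on an aromatic carbon. Among the measured compounds shown here, no step between measured compounds exists to lean on, and a step starting from a limit cannot be sized. Given that both known values lie at the limit, the likeliest outcome is that compound 3 also reports only a limit, with some chance of a modest gain.

Compound 3 is expected to give about 15000 nM, within 3000 nM to 40000 nM. The implied step an at least 1.3-fold lower number from compound 1 to compound 3 (0.12 log units; that floor lies within the scatter) is an expectation only, not a measurement.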

Compound 3, half-maximal inhibitory concentration: 10800 nM
Compound 3: the middle estimate sits 1.4-fold (0.14 log units) above what was measured, and the stated range covers the measured number.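

The change shows that this aromatic carbon, two ring bonds from the ring nitrogen, can carry a group as large as 1-benzofuran-2-yl, with 9 heavy atoms in place of the single iodine, and that the compound can still give a measured number in this assay. As far as these compounds go, putting 1-benzofuran-2-yl in place of iodo gives an at least 1.8-fold lower number from compound 1 to compound 3 (0.26 log units; that floor lies within the scatter); compound 1 has only a limit, so the true size of this step is unknown, and its floor alone does not establish a gain beyond ordinary repeat variation. Compound 3 is now the one compound here with a measured number, which gives any further change at this carbon a starting point that can be sized, while the other two values remain limits: the limit of > 20000 nM in this assay, at which 2 of the 3 values shown sit.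

The compounds shown leave open whether both fused rings of the 1-benzofuran-2-yl group are needed for a measurable value, or whether a single phenyl ring, an amine or a short alkyl chain on the same carbon would give one too. They also leave open how far the number can fall with other groups at this carbon, on the core of compound 1.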